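The compounds below may be only part of what the source reports. "The series", "measured", "known", "first", "only" and "open" are said of these compounds alone.

Of the compounds shown here, two have so far been measured in an ADME assay on the whole organism (strain Sprague-Dawley) for pharmacokinetics, with Rattus norvegicus as the target, read by LC-MS, at a dose of 50 mg/kg by the oral route; on this read-out lower numbers stand for lower oral bioavailability and higher numbers for higher oral bioavailability. Compound 1 `CCC(CC)O[C@@H]1C=C(C(=O)O)C[C@H](NC(C)=N)[C@H]1NC(C)=O` gives 3.9%. Compound 2 `CCOC(=O)C1=C[C@@H](OC(CC)CC)[C@H](NC(C)=O)[C@@H](N/C(C)=N/O)C1` gives 31.4%, the higher of the two numbers, and compound 1 lies well below it, beyond the usual scatter. Compound 3 `CCOC(=O)C1=C[C@@H](OC(CC)CC)[C@H](NC(C)=O)[C@@H](N/C(N)=N\O)C1` has not yet been measured; it differs from compound 2 by a group of 4 heavy atoms (1 carbon, 2 nitrogen, 1 oxygen; no ring) in place of a group of 4 heavy atoms (2 carbon, 1 nitrogen, 1 oxygen; no ring), on an amine nitrogen. Going by the values given here, no matched pair carrying this change has been measured, so the step of a number 6.4 percentage points lower from compound 2 to compound 3 (within the scatter) is expected to be small, slightly downward if anything, and within the scatter. Compound 3 is accordingly estimated at 25%, with a likely range from 10% to 45%.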

Compound 3, oral bioavailability in the Rattus norvegicus assay: 1.5%
The estimate for compound 3 lay 23.5 percentage points above the measured number, outside the stated range (below it).
By their numbers in the Rattus norvegicus assay, from the lowest: compounds 3 and 1 (each within the scatter of the next); then compound 2.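

In the Rattus norvegicus assay the change on the amine nitrogen gives a number 29.9 percentage points lower from compound 2 to compound 3 (beyond the scatter), so oral bioavailability responds to this position even when one group of 4 heavy atoms replaces another. In a physicochemical assay for solubility, read by HPLC, in phosphate buffer, with a stated time of 20 min, at pH 2.0 (a higher number here means a more soluble compound, a lower number a less soluble compound), compound 2 gives > 50000000 nM, which is a limit of the assay. In the physicochemical assay compound 3 gives > 50000000 nM, again a limit of the assay.

As far as these compounds go, the step between them in solubility cannot be read, because both values are limits: the limit of > 50000000 nM in the physicochemical assay, at which 2 of the 2 values shown sit. Whether a plain amine or a longer chain on this nitrogen would keep the oral bioavailability of compound 2 stays open.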